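Adding an amino group to a trimethoxystyryl sulfonamide

A few compounds are considered here, and "the series" means these few. Any claim that something is new, unique, unknown or untested is made for them only; others in the source may bear on it.

Of the compounds shown here, two sharing one core have been measured in a functional assay on K562 cells (Homo sapiens) for cytotoxicity, read by trypan blue exclusion, with a stated time of 96 h; a lower number here means a stronger inhibitor, a higher number a weaker inhibitor. Compound 1 `COc1ccc(NS(=O)(=O)/C=C/c2ccc(OC)cc2OC)cc1` gives 15000 nM. Compound 2 `COc1ccc(NS(=O)(=O)/C=C/c2c(OC)cc(OC)cc2OC)cc1` gives 75 nM, the lower of the two numbers. Among the compounds with values here, the only measured step is a 200-fold lower number from compound 1 to compound 2 (2.30 log units; beyond the scatter), and it changes a ring that is not touched by the change considered next.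

Compound 3 `COc1cc(OC)c(/C=C/S(=O)(=O)Nc2ccc(OC)c(N)c2)c(OC)c1` differs from compound 2 in one place: amino in place of hydrogen on an aromatic carbon. Within the data shown here, no measured step concerns this ring or this group, so the direction and size of the change cannot be read from the data; the step from compound 1 to compound 2 tells only that compound 2 sits at the low end of what is known so far. Without a comparable step, the expectation is that compound 3 stays close to compound 2, with a slightly lower number favoured but nothing beyond the scatter, an expected step of a 1.7-fold lower number from compound 2 to compound 3 (0.22 log units; within the scatter). Compound 3 is therefore estimated at 45 nM, within a range from 8 nM to 250 nM.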

Compound 3, half-maximal inhibitory concentration: 3 nM
For compound 3 the middle estimate is 15-fold (1.18 log units) above the measured one, and the stated range ends above it.
By their numbers in this assay, from the lowest: compound 3; then compound 2; then compound 1.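

In this assay, within the data shown here, the change from 4-methoxyphenyl to 3-amino-4-methoxyphenyl gives a 25-fold lower number from compound 2 to compound 3 (1.40 log units; beyond the scatter) and so shows that this ring, which no earlier step touched, also responds to a very small edit. A single added amino group, ortho to a methoxy group and meta to a large group, brings only one heavy atom, yet its step lies far beyond the scatter. Alongside a 200-fold lower number from compound 1 to compound 2 (2.30 log units; beyond the scatter) on the other side of the molecule, this means that one-group changes on two different rings of the shared core have each moved the number strongly, though this rests on only these three compounds. Nothing given here explains the size of the amino step.

The compounds shown leave open whether the amino group itself matters or whether another group in the same place, such as a hydroxy group, a methylamino group or an acetamide, would give a similar number. They also leave open whether an amino group would have the same effect on a different aromatic carbon of this ring, or in compound 1, which lacks the extra methoxy group of compound 2.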